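A few compounds are considered here, and "the series" means these few. Any claim that something is new, unique, unknown or untested is made for them only; others in the source may bear on it.

Measured so far in an ADME assay on Vero cells (Chlorocebus sabaeus) for cytotoxicity, read by MTT assay, with a stated time of 96 h; a higher number here means that more compound is tolerated, a lower number that less compound is tolerated:

compound 1, `COc1cc(NCc2scnc2C)ccc1-c1cnco1`: 73700 nM
compound 2, `COc1cc(NCc2cncs2)ccc1-c1cnco1`: 232000 nM

Within the data shown here, compound 2 gives the highest of the two numbers in this assay; its nearest neighbour is compound 1, and the single measured step runs a 3.1-fold higher number from compound 1 to compound 2 (0.50 log units; beyond the scatter), a hydrogen in place of methyl on an aromatic carbon.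

Compound 3, `CCc1ccc(CNc2ccc(-c3cnco3)c(OC)c2)s1`, has not yet been measured. Relative to compound 2 the change is 5-ethylthiophen-2-yl in place of 1,3-thiazol-5-yl on a saturated chain carbon bound to a nitrogen on an aromatic ring. Among the measured compounds shown here, the only step available for comparison is a 3.1-fold higher number from compound 1 to compound 2 (0.50 log units; beyond the scatter), where removing a methyl raised the number beyond the scatter; the present change runs the other way in that an alkyl group enters, while the ring itself also changes, for which no step exists. On that basis a modest drop in this assay is expected for compound 3, a 2.9-fold lower number from compound 2 to compound 3 (0.46 log units; beyond the scatter), with wide uncertainty. Compound 3 is estimated at 80000 nM, in the range 30000 nM to 220000 nM.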

Compound 3, half-maximal cytotoxic concentration: 13600 nM
The estimate for compound 3 lay 5.9-fold (0.77 log units) above the measured number; measured number below the stated range.
By their numbers in this assay, from the lowest: compound 3; then compound 1; then compound 2.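

In this assay, among these compounds, the position on a saturated chain carbon bound to a nitrogen on an aromatic ring tolerates less of this exchange than the single methyl step suggested: 5-ethylthiophen-2-yl in place of 1,3-thiazol-5-yl gives a 17-fold lower number from compound 2 to compound 3 (1.23 log units; beyond the scatter), a large step. Measured against 4-methyl-1,3-thiazol-5-yl, the same group gives a 5.4-fold lower number from compound 1 to compound 3 (0.73 log units; beyond the scatter), a modest step, so compound 3 stands beyond the scatter below both thiazole compounds. Nothing available explains the size of this drop.

As far as these compounds go, the change alters the ring and the alkyl group together, so the share of each stays open. An unsubstituted thiophen-2-yl would separate the two, and a 5-methylthiophen-2-yl or a longer chain in place of the ethyl would show whether the number follows chain length.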